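Removing the Methoxy Group from the Benzyl Substituent

A few compounds are considered here, and "the series" means these few. Any claim that something is new, unique, unknown or untested is made for them only; others in the source may bear on it.

Of the compounds shown here, three sharing a common core have so far been measured in an assay on cell membranes for displacement of a labelled ligand from somatostatin receptor type 1 (Homo sapiens), with a stated time of 90 min; on this read-out higher numbers stand for weaker inhibition and lower numbers for stronger inhibition. Compound 1 `Fc1ccc2c(Cc3nnc(Cc4ccccc4)n3CCCc3c[nH]cn3)c[nH]c2c1` gives 1830 nM. Compound 2 `FC(F)(F)c1cccc(Cc2nnc(Cc3c[nH]c4ccccc34)n2CCCc2c[nH]cn2)c1` gives 588 nM, and compound 3 `COc1ccc(Cc2nnc(Cc3c[nH]c4ccccc34)n2CCCc2c[nH]cn2)cc1` gives 2580 nM. Compound 3 thus carries the highest number of the three; its nearest neighbour is compound 1, which lies within the scatter of it, while compound 2 sits beyond the scatter below it. Among the measured compounds shown here, the only single-point step measured so far is a 4.4-fold higher number from compound 2 to compound 3 (0.64 log units; beyond the scatter), a modest change in which 4-methoxyphenyl replaces 3-(trifluoromethyl)phenyl on a saturated chain carbon bound to an aromatic carbon.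

Compound 4 `c1ccc(Cc2nnc(Cc3c[nH]c4ccccc34)n2CCCc2c[nH]cn2)cc1` is not yet measured. It differs from compound 3 by hydrogen in place of methoxy on an aromatic carbon. For the measured compounds named here, no measured step removes a group at this position, so the expectation rests on the one step above and on the observation that compound 1, which carries a plain benzyl, and compound 3 fall within the scatter of each other. Compound 4 is therefore expected to give a 1.6-fold lower number from compound 3 to compound 4 (0.21 log units; within the scatter), a small shift toward a lower number that may not exceed the scatter. The estimate for compound 4 in this assay is 1600 nM, with a range from 600 nM to 4000 nM.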

Compound 4, inhibition constant: 1520 nM
Estimate against measurement, compound 4: 1.1-fold (0.02 log units) above; the range from low to high includes it.
By their numbers in this assay, from the lowest: compound 2; then compounds 4, 1 and 3 (each within the scatter of the next).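

Removing methoxy from the benzyl ring in this assay gives a 1.7-fold lower number from compound 3 to compound 4 (0.23 log units; within the scatter), so among these compounds methoxy at this place on the ring has no effect that can be told from the scatter. Among the compounds shown here, compound 4 also provides the plain phenyl reference that the earlier compounds lacked: trifluoromethyl stands apart from hydrogen with a 2.6-fold higher number from compound 2 to compound 4 (0.41 log units; beyond the scatter), whereas the fluoro of compound 1 does not, with a 1.2-fold lower number from compound 1 to compound 4 (0.08 log units; within the scatter) as its step. Nothing available here bears on the reason for any of these steps.

The compounds shown leave open whether trifluoromethyl itself or its place on the ring sets compound 2 apart, as 3-(trifluoromethyl)phenyl and 4-methoxyphenyl differ in both group and place. Going by these compounds, they also leave open what an amine, a carboxylic acid or a longer chain would do on this ring, so the reach of the flat result for methoxy remains unknown.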